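This account rests on a few compounds, and the source may have more. Where it says the series, first, only, none or still open, it means among the compounds named here.

Compound 2, with the structure `CCOC(=O)NC1CC(C)(C)Oc2ccc(Cl)cc21`, has in a functional assay on T98G cells (Homo sapiens) for inhibition, read by MTT assay, with a stated time of 72 h (a lower number here means a stronger inhibitor, a higher number a weaker inhibitor), only the entry "not determined" (no result reported): no number was reported for it, so it cannot be placed among the measured compounds. Two related compounds do have numbers. Compound 1 `CC1(C)CC(NC(=S)Nc2cccc(Cl)c2)c2cc(Br)ccc2O1` gives 9000 nM in this assay, and compound 3 `CC(C)NC(=S)NC1CC(C)(C)Oc2ccc(Cl)cc21` gives 91000 nM in this assay. Compound 4 `CC1(C)CC(NC(=O)Nc2ccc(Cl)cc2)c2cc(Cl)ccc2O1` is the compound still to be measured. Relative to compound 2 it differs in one place: (4-chlorophenyl)amino in place of ethoxy on a carbonyl carbon. For the measured compounds named here, since compound 2 has no number, no step in this assay can be computed between compound 2 and compound 4, and no direction can be stated from those two alone. What the two measured compounds show is that compound 1, which like compound 4 carries an aromatic ring bearing chlorine, is far stronger than compound 3. On that basis compound 4 is expected to land nearer compound 1 than compound 3, with an estimated value of 12000 nM, most likely between 3000 nM and 50000 nM.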

Compound 4, half-maximal inhibitory concentration: 33000 nM
For compound 4 the middle estimate is 2.8-fold (0.44 log units) below the measured one, within the range that was stated.
By their numbers in this assay, from the lowest: compound 1; then compound 4; then compound 3.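

No step can be read between compound 2 and compound 4 in this assay, so the result for compound 4 stands alone. Left open is how replacing ethoxy with (4-chlorophenyl)amino on the carbonyl carbon changes inhibition, and no measurement shown offers an explanation.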